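A few compounds are considered here, and "the series" means these few. Any claim that something is new, unique, unknown or untested is made for them only; others in the source may bear on it.

Compound 1 `O=C(Nc1ccc(OC(F)(F)F)cc1)NC1CCN(C(=O)c2ccoc2)CC1` was examined in a physicochemical assay for solubility, read by mass spectrometry, in phosphate buffer, with a stated time of 24 h, at pH 7.4 (a higher number here means a more soluble compound, a lower number a less soluble compound), where compound 1 gives 7.6 ug/mL. In this assay compound 2 `CC(C)C(=O)N1CCC(NC(=O)Nc2ccc(C(F)(F)F)c(F)c2)CC1` gives 5.9 ug/mL. The two numbers sit within the scatter of each other, so compound 1 cannot be set apart from compound 2 on this reading. Compound 3 `O=C(Nc1ccc(OC(F)(F)F)cc1)NC1CCN(C(=O)[C@@H]2CCOC2)CC1` differs from compound 1 in one place: oxolan-3-yl in place of furan-3-yl on a carbonyl carbon. For the measured compounds named here, no pair of measured compounds shows this change, so nothing here fixes its size. A small rise is expected for compound 3, about the width of the scatter, as the step of a 1.6-fold higher number from compound 1 to compound 3 (0.20 log units; within the scatter) states. Compound 3 is therefore expected to give 12 ug/mL, within 5 ug/mL to 30 ug/mL.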

Compound 3, solubility: 23 ug/mL
Estimate against measurement, compound 3: 1.9-fold (0.28 log units) below; the measured number falls inside the stated range.
By their numbers in this assay, from the lowest: compounds 2 and 1 (each within the scatter of the next); then compound 3.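

In this assay the swap of furan-3-yl for oxolan-3-yl on this carbonyl carbon gives a 3.0-fold higher number from compound 1 to compound 3 (0.48 log units; beyond the scatter) and so shows that this position can clearly move the number. The two groups have the same counts of heavy atoms and hydrogen-bond acceptors, so the printed differences are the loss of aromaticity and the defined stereocentre. Nothing measured here gives a reason for the rise. Still open, going by these compounds, is how the mirror-image oxolan-3-yl would read, and how a group carrying an amine or a carboxylic acid would read at this carbonyl carbon.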